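Swapping methoxy for bromo on the phenyl ring

The compounds below may be only part of what the source reports. "The series", "measured", "known", "first", "only" and "open" are said of these compounds alone.

Measured compounds and their read-outs:
Compound 1, `CC1(C)C(=O)N(c2ccccc2Cl)c2ncccc21`: 3%
Compound 2, `COc1ccc(N2C(=O)C(C)(C)c3cccnc32)cc1`: 42%
Compound 3, `CCC1(C)C(=O)N(c2ccccc2)c2ncccc21`: 12%

All three were tested in a functional assay on the whole organism (Pleural cavity) for inhibition, with Rattus norvegicus as the target, at a dose of 25 mg/kg; a lower number here means less inhibition, a higher number more inhibition at the dose given (going by the name of the read-out). In this assay compound 2 gives 42%, the highest of the three numbers. The nearest of the others is compound 3, whose read-out lies lower by a gap beyond the scatter. Compound 1 lies further still below compound 2, also beyond the scatter. So compound 2 stands clearly apart from both companions on the numbers at hand.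

The next compound, compound 4, `CC1(C)C(=O)N(c2ccc(Br)cc2)c2ncccc21`, differs from compound 2 in one place: bromo in place of methoxy on an aromatic carbon. The group leaves from an aromatic carbon of the six-membered carbon-only ring, para to a large group, and bromo enters at the same spot.

Among the measured compounds shown here, no pair of measured compounds differs in just one place, so no step of this kind has been seen here. Given that compound 2 is the only one of the three with a high read-out, and the other two sit low, a downward step is expected, moderate in size and beyond the scatter. Compound 4 is therefore estimated at 25%, with a range from 5% to 50%. This estimate means a step of a number 17 percentage points lower from compound 2 to compound 4 (beyond the scatter).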

Compound 4, a percentage reported as inhibition, in the whole organism at one dose (the size of the read-out at that dose, not a potency): 55%
Estimate against measurement, compound 4: 30 percentage points below; the measured number lies above the stated range.
By their numbers in this assay, from the lowest: compounds 1 and 3 (each within the scatter of the next); then compound 2; then compound 4.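

In this assay, among the compounds shown here, putting bromo in place of methoxy on the aromatic carbon para to a large group gives a number 13 percentage points higher from compound 2 to compound 4 (beyond the scatter), the first direct reading of a change at this position. Within this pair, the read-out stays high and even rises when methoxy, with its oxygen and its hydrogen-bond acceptor, is replaced by a single bromine atom that counts no acceptor, so this oxygen is not required for inhibition in this assay. Nothing measured here explains the rise, so this single pair records the change in the read-out without giving a reason for it.

The compounds shown leave open how an amine, a carboxylic acid, a trifluoromethyl group or a plain hydrogen on this same carbon would compare with bromo and methoxy, so two groups cannot yet show a trend at this position. They also leave open whether the rise would hold at other doses, as the read-out gives the size of the inhibition at one dose and is not a potency.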